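Replacing the hydroxyphenyl amine by a methoxybenzyl amine

The source may hold more compounds than are shown below. What is called first, only, known or untested is meant among the compounds shown, and "the series" means these compounds.

Among the compounds with values here, compound 2 `COc1cc(/C=C/c2nc(Nc3ccc(O)cc3)c3sccc3n2)cc(OC)c1OC` gives 2300000 nM in an ADME assay on L02 cells (Homo sapiens) for cytotoxicity, read by MTT assay (on this read-out higher numbers stand for weaker inhibition and lower numbers for stronger inhibition), the higher of the two numbers known, the other being compound 1 `COc1ccc(Nc2nc(/C=C/c3cc(OC)c(OC)c(OC)c3)nc3ccsc23)cc1` at 279000 nM. Compound 3 `COc1ccc(CNc2nc(/C=C/c3cc(OC)c(OC)c(OC)c3)nc3ccsc23)cc1` differs from compound 2 by 4-methoxybenzyl in place of 4-hydroxyphenyl on a nitrogen on an aromatic ring. Within the data shown here, the one step known, an 8.2-fold higher number from compound 1 to compound 2 (0.92 log units; beyond the scatter), bears on this change only in its oxygen part, since removing the methyl there raised the number; restoring the methyl should lower it again, while the added methylene is untested. Compound 3 is therefore expected to show a 5.8-fold lower number from compound 2 to compound 3 (0.76 log units; beyond the scatter), with an estimate of 400000 nM and a range of 130000 nM to 1300000 nM.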

Compound 3, half-maximal inhibitory concentration: 2050000 nM
Compound 3: middle estimate off by 5.1-fold (0.71 log units), on the low side; measured number outside the range, above it.
By their numbers in this assay, from the lowest: compound 1; then compounds 3 and 2 (each within the scatter of the next).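

In this assay, 4-methoxybenzyl in place of 4-hydroxyphenyl on this nitrogen gives a 1.1-fold lower number from compound 2 to compound 3 (0.05 log units; within the scatter), so the two groups cannot be told apart here. Set against 4-methoxyphenyl, the same group gives a 7.3-fold higher number from compound 1 to compound 3 (0.87 log units; beyond the scatter), so the methoxy group alone does not keep the lower number of compound 1 once the methylene enters. Nothing at hand gives a reason for this. Still open, as far as these compounds go, is how a 4-hydroxybenzyl group, or a longer chain such as 4-methoxyphenethyl, would read on this nitrogen.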